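The source may report more compounds than this note shows. Statements on the series, on what has been measured and on what is new or still open speak of the compounds shown alone.

Measured compounds:
Compound 1, `CC(=O)Oc1ccc(/C=C/C(=O)O)cc1OC(C)=O` — in an assay for inhibition of Polyunsaturated fatty acid 5-lipoxygenase (Homo sapiens), read by HPLC, with a stated time of 10 min (a lower number here means a stronger inhibitor, a higher number a weaker inhibitor), compound 1 gives > 10000 nM, which is a limit of the assay rather than a number.
Compound 2, `C#CCCCCOC(=O)/C=C/c1ccc(OC(C)=O)c(OC(C)=O)c1` — compound 2 gives 920 nM.
Compound 3, `C#CCCCCCOC(=O)/C=C/c1ccc(OC(C)=O)c(OC(C)=O)c1` — compound 3 gives 470 nM.

Compound 1 therefore stands at the weak end of what is shown, with only a limit known (the limit of > 10000 nM in this assay, at which 1 of the 3 values shown sits). Compound 4 is `CC(=O)Oc1ccc(/C=C/C(=O)CCCN=[N+]=[N-])cc1OC(C)=O`, and it differs from compound 1 in one place: 3-azidopropyl in place of hydroxy on a carbonyl carbon. The carboxy group of compound 1 thus becomes a (3-azidopropyl)carbonyl ketone.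

The measured steps that bear on this both start from compound 1 and also remove the free acid hydrogen: an at least 10-fold lower number from compound 1 to compound 2 (1.03 log units; beyond the scatter) and an at least 21-fold lower number from compound 1 to compound 3 (1.32 log units; beyond the scatter). Both were large and both pointed to stronger inhibition. Whether a chain carrying an azide behaves like a chain carrying an alkyne cannot be read from these three compounds, and the two chains that were measured differ only in a step within the scatter, a 2.0-fold lower number from compound 2 to compound 3 (0.29 log units; within the scatter).

Given that both recorded departures from the acid of compound 1 gave large gains, compound 4 is expected to show a step of an at least 6.6-fold lower number from compound 1 to compound 4 (0.82 log units; beyond the scatter). Compound 4 is therefore estimated at 1500 nM, with a range from 400 nM to 8000 nM.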

Compound 4, half-maximal inhibitory concentration: 1300 nM
For compound 4 the middle estimate is 1.2-fold (0.06 log units) above the measured one; the range from low to high includes it.
By their numbers in this assay, from the lowest: compounds 3, 2 and 4 (each within the scatter of the next, the first and the last beyond it). At a limit, above all of these: compound 1.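

In this assay, replacing hydroxy with 3-azidopropyl on the carbonyl carbon gives an at least 7.6-fold lower number from compound 1 to compound 4 (0.88 log units; beyond the scatter), so the gain over the acid also appears with a ketone ending in an azide, not only with esters ending in an alkyne. The size of that step is only a bound, as the value for compound 1 is a limit of the assay: the limit of > 10000 nM in this assay, at which 1 of the 4 values shown sits. Against the ester chains, the ketone shows a 1.4-fold higher number from compound 2 to compound 4 (0.15 log units; within the scatter), which leaves it level with the hex-5-yn-1-yl ester, and a 2.8-fold higher number from compound 3 to compound 4 (0.44 log units; beyond the scatter), a modest loss against the hept-6-yn-1-yl ester.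

Each change alters the link to the carbonyl carbon, the chain length and the chain end together, and the compounds shown cannot separate these. A plain hexyl ester, an amide or a longer azide-bearing chain would be needed to tell them apart.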